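The compounds below may be only part of what the source reports. "The series", "measured", "known", "first", "only" and "open" are said of these compounds alone.

Working notes on the series. In an assay on isolated protein for inhibition of carboxypeptidase B2 (Homo sapiens), read by spectrophotometry, with stated times of 10 min and 30 min (on this read-out higher numbers stand for weaker inhibition and lower numbers for stronger inhibition), compound 1 `CCOC(=O)C(CCCCCN)CSC(C)=O` gives 310000 nM, while compound 2 `CCOC(=O)C(CCCCCN)C[Se]C(=O)CC` gives 1400 nM, the lowest of the two numbers shown; the only measured step, a 220-fold lower number from compound 1 to compound 2 (2.35 log units; beyond the scatter), is the sole precedent. Compound 3 `CCOC(=O)C(CS)CCCCCN` differs from compound 2 by one sulfur atom in place of a group of 5 heavy atoms (3 carbon, 1 oxygen, 1 selenium; no ring), on a saturated chain carbon, two bonds along the chain from a carbonyl carbon. Going by the values given here, no measured step swaps the whole acyl-chalcogen group for a bare sulfanyl, so the expectation rests loosely on that one large step. The number for compound 3 in this assay is estimated at 400 nM, with a range of 40 nM to 4000 nM, expected as a 3.5-fold lower number from compound 2 to compound 3 (0.54 log units; beyond the scatter).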

Compound 3, half-maximal inhibitory concentration: 62000 nM
Estimate against measurement, compound 3: 160-fold (2.19 log units) below; measured number outside the range, above it.
By their numbers in this assay, from the lowest: compound 2; then compound 3; then compound 1.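

At this position the bare sulfanyl does not keep the low number of the selenium-bearing acyl group, giving a 44-fold higher number from compound 2 to compound 3 (1.65 log units; beyond the scatter). Taking the acetyl off the sulfur gives only a 5.0-fold lower number from compound 1 to compound 3 (0.70 log units; beyond the scatter), so the acyl-free thiol still does not reach the number of compound 2. No measurement bears on the cause of either step.

Selenium and the longer acyl chain change together in compound 2, so a propanoyl on sulfur or an acetyl on selenium would be needed to separate them. On these data alone, a carboxylic acid in place of the ethyl ester also remains open.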